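The compounds below may be only part of what the source reports. "The series", "measured", "known", "first", "only" and "open" are said of these compounds alone.

The measured compounds are:

Compound 1 `COc1ccc(Nc2nc(-c3cccc(F)c3)nc3ccc(F)cc23)cc1`, with 47300 nM in a functional assay on MDA-MB-231 cells (Homo sapiens) for cytotoxicity, read by MTT assay, with a stated time of 48 h; a lower number here means a stronger inhibitor, a higher number a weaker inhibitor.
Compound 2 `Fc1cccc(Nc2nc(-c3cccc(F)c3)nc3ccc(F)cc23)c1`, with 47600 nM in this assay.
Compound 3 `Fc1cccc(-c2nc(Nc3ccc(Cl)cc3)c3cc(F)ccc3n2)c1`, for which this assay gives only the limit > 50000 nM.

Compound 3 therefore stands at the limit of the assay, (the limit of > 50000 nM in this assay, at which 1 of the 3 values shown sits), and no number is known for it. The two steps that lead to it, an at least 1.0-fold higher number from compound 1 to compound 3 (0.02 log units; that floor lies within the scatter) and an at least 1.0-fold higher number from compound 2 to compound 3 (0.02 log units; that floor lies within the scatter), both sit within the scatter, as does a 1.0-fold higher number from compound 1 to compound 2 (0.00 log units; within the scatter); across these three compounds the assay shows no difference it can resolve.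

Compound 4 `Fc1cccc(-c2nc(Nc3cccc(Cl)c3)c3cc(F)ccc3n2)c1` differs from compound 3 only in the arrangement of the same atoms: 3-chlorophenyl in place of 4-chlorophenyl on a nitrogen on an aromatic ring. For the measured compounds named here, the steps that bear on this change are those at the same nitrogen, a 1.0-fold higher number from compound 1 to compound 2 (0.00 log units; within the scatter) and an at least 1.0-fold higher number from compound 2 to compound 3 (0.02 log units; that floor lies within the scatter), and neither moved beyond the scatter. A step of that kind in this assay is therefore expected to stay within the scatter, with no direction to it, and since compound 3 sits at the limit, compound 4 is expected to lie at or just beyond it. Compound 4 is estimated at 60000 nM, within 30000 nM to 150000 nM, which means an expected step that the limit leaves unreadable from compound 3 to compound 4.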

Compound 4, half-maximal inhibitory concentration: > 50000 nM
Compound 4 was reported as a limit; the forecaster's own chance of this, stated with the estimate: 65%; the middle value lies beyond the limit too.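

Moving the chloro group from 4-chlorophenyl to 3-chlorophenyl on the nitrogen leaves compound 4, like compound 3, reported only as a limit in this assay, so the step between these two cannot be read, in size or in direction: the limit of > 50000 nM in this assay, at which 2 of the 4 values shown sit.

The two steps that can be read, an at least 1.0-fold higher number from compound 2 to compound 4 (0.02 log units; that floor lies within the scatter) and an at least 1.0-fold higher number from compound 1 to compound 4 (0.02 log units; that floor lies within the scatter), both have floors within the scatter, so they resolve no difference. What this adds is that both chlorophenyl arrangements at this nitrogen now end at the limit, while compound 1, with 4-methoxyphenyl, and compound 2, with 3-fluorophenyl, carry numbers.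

The compounds shown leave open whether compound 3 and compound 4 differ at all beyond the limit. They also leave open whether another group on this phenyl ring, such as an amine or a carboxylic acid in place of the chloro group, would give a number in this assay that stands clear of the scatter around these values.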